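The source may report more compounds than this note shows. Statements on the series, on what has been measured and on what is new or still open speak of the compounds shown alone.

Compound 1, `CCCCCCC#Cc1cc2cn(COCCO)c(=O)nc2o1`: > 200000 nM
Compound 2, `CCCCCCCCCc1cc2cn(COCCO)c(O)nc-2n1`: > 80000 nM

Both measured compounds were tested in a functional assay on HEL cells (Homo sapiens), read by microscopy; on this read-out lower numbers stand for higher toxicity in this test and higher numbers for lower toxicity in this test. Compound 1 gives > 200000 nM, which is a limit of the assay and not a number. Compound 2 likewise gives > 80000 nM, again a limit rather than a measured number. Among the measured compounds shown here, compound 1 therefore stands at a limit, and the one other value shown is also a limit; the two values cannot be placed in order against each other, and no step between them is reported.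

Compound 3, `CCCCCCCCC#Cc1cc2cn(COCCO)c(=O)nc2o1`, has not yet been measured. It differs from compound 1 by ethyl in place of hydrogen on a saturated chain carbon, six bonds along the chain from a triple-bonded carbon. The saturated chain simply grows, the added ethyl sitting six bonds along the chain from a triple-bonded carbon.

For the measured compounds named here, with no measured step to lean on and both known values sitting at limits, the expected step in this assay is one of no size beyond the scatter, a number no higher from compound 1 to compound 3 (the limit leaves the size open). Compound 3 is thus estimated to give 200000 nM, with a range from 50000 nM to 400000 nM, and most likely the result will again be only a limit.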

Compound 3, minimum cytotoxic concentration: >= 20000 nM
Compound 3: no number, only a limit; the forecaster's own chance of this, stated with the estimate: 70%; the middle value is on the limit's open side.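

In this assay compound 3 gives >= 20000 nM, which is a limit and not a number. Compound 1 gives > 200000 nM, also a limit, so no step can be read between these two compounds. The compounds shown leave open whether ethyl in place of hydrogen on this chain changes the result in this assay at all.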